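Permeability notes: chloro in place of methoxy

A few compounds are considered here, and "the series" means these few. Any claim that something is new, unique, unknown or untested is made for them only; others in the source may bear on it.

Measured compounds:
compound 1 `COc1ccc(NC(=O)Nc2cc(C)nc3ccccc23)cc1` — 787 10^-6 cm/s
compound 2 `Cc1cc(NC(=O)Nc2ccc(F)cc2)c2ccccc2n1` — 801 10^-6 cm/s
compound 3 `Cc1cc(NC(=O)Nc2ccc3[nH]cnc3c2)c2ccccc2n1` — 2 10^-6 cm/s

In an ADME assay for permeability, using PAMPA, at pH 7.4 (on this read-out lower numbers stand for lower permeability and higher numbers for higher permeability), compound 1 gives 787 10^-6 cm/s, the second highest of the three numbers. Compound 2 gives 801 10^-6 cm/s, within the scatter of compound 1, while compound 3 gives 2 10^-6 cm/s, beyond the scatter on the low side. Compound 4 `Cc1cc(NC(=O)Nc2ccc(Cl)cc2)c2ccccc2n1` is not yet measured. It differs from compound 1 as follows: chloro in place of methoxy on an aromatic carbon. Within the data shown here, the one measured step that bears on this is a 1.0-fold higher number from compound 1 to compound 2 (0.01 log units; within the scatter), another exchange of the methoxy for a halogen on that aromatic carbon, which stayed within the scatter. No step beyond the scatter is therefore expected in this assay for compound 4. Compound 4 is expected to give about 800 10^-6 cm/s, estimated between 400 10^-6 cm/s and 1500 10^-6 cm/s, which means an expected 1.0-fold higher number from compound 1 to compound 4 (0.01 log units; within the scatter).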

Compound 4, apparent permeability: 537 10^-6 cm/s
Compound 4: the middle estimate sits 1.5-fold (0.17 log units) above what was measured; the range from low to high includes it.
By their numbers in this assay, from the lowest: compound 3; then compounds 4, 1 and 2 (each within the scatter of the next).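

In this assay, a second halogen on the aromatic carbon para to a large group leaves the read-out within the scatter of both earlier neighbours (a 1.5-fold lower number from compound 1 to compound 4 (0.17 log units; within the scatter); a 1.5-fold lower number from compound 2 to compound 4 (0.17 log units; within the scatter)). Methoxy, fluoro and chloro at this place therefore cannot be told apart on this read-out, and the fluoro result no longer stands alone. No measured evidence explains this result.

Open, as far as these compounds go, is whether this holds for an amine or a carboxylic acid at the same place. From the compounds shown here alone, a longer chain, such as ethoxy, also remains open.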